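Swapping the nitro group of compound 3 for methylsulfonyl

This account rests on a few compounds, and the source may have more. Where it says the series, first, only, none or still open, it means among the compounds named here.

Measured compounds:
compound 1, `CCCON1C(=O)[C@@H](NC(=O)OCCCCC2CCCCC2)[C@@H]1C`, 133 nM
compound 2, `CC(=O)CCCON1C(=O)[C@@H](NC(=O)OCCCCC2CCCCC2)[C@@H]1C`, 75 nM
compound 3, `C[C@H]1[C@H](NC(=O)OCCCCC2CCCCC2)C(=O)N1Oc1ccc([N+](=O)[O-])cc1`, 17 nM

In an assay on HEK293 cells for inhibition of N-acylethanolamine-hydrolyzing acid amidase (Homo sapiens), read by fluorescence, with stated times of 10 min and 50 min (on this read-out lower numbers stand for stronger inhibition and higher numbers for weaker inhibition), compound 3 gives the lowest number of the three and is the most potent: the changes on the oxygen were a 7.8-fold lower number from compound 1 to compound 3 (0.89 log units; beyond the scatter) and a 4.4-fold lower number from compound 2 to compound 3 (0.64 log units; beyond the scatter), both beyond the scatter, while a 1.8-fold lower number from compound 1 to compound 2 (0.25 log units; within the scatter) stayed within it. Compound 4, `C[C@H]1[C@H](NC(=O)OCCCCC2CCCCC2)C(=O)N1Oc1ccc(S(C)(=O)=O)cc1`, differs from compound 3 by methylsulfonyl in place of nitro on an aromatic carbon. For the measured compounds named here, none of the measured steps alters the substituent on the aromatic ring; the two steps that reach compound 3 replace a chain with the whole 4-nitrophenyl group and show only that this group lowers the number in this assay. As far as these compounds go, the effect of the group on the ring itself is untested here, so the expectation for compound 4 rests on the value of compound 3, 17 nM, with wide uncertainty. Compound 4 is therefore expected to show a 1.5-fold higher number from compound 3 to compound 4 (0.17 log units; within the scatter) in this assay, a step not beyond the scatter. The estimate for compound 4 is 25 nM, with a range from 9 nM to 70 nM.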

Compound 4, half-maximal inhibitory concentration: 6 nM
Beside the measured number, compound 4's estimate is 4.2-fold (0.62 log units) above it, and the stated range ends above it.
By their numbers in this assay, from the lowest: compound 4; then compound 3; then compounds 2 and 1 (each within the scatter of the next).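

In this assay the group on the aromatic ring itself proves to matter: there is a 2.8-fold lower number from compound 3 to compound 4 (0.45 log units; beyond the scatter) in this assay, with methylsulfonyl in place of nitro para to a large group. The earlier compounds shown here showed only what the whole 4-nitrophenyl group did in place of a chain on the oxygen, whereas 4-(methylsulfonyl)phenyl gives a 13-fold lower number from compound 2 to compound 4 (1.10 log units; beyond the scatter) and a 22-fold lower number from compound 1 to compound 4 (1.35 log units; beyond the scatter) and so shows that nitro is not needed for a low number here. No measurement at hand explains the difference between the two groups.

Still open, as far as these compounds go, is how a nitrile, a carboxylic acid, an amine or plain hydrogen would fare on the same aromatic carbon. For the compounds shown here, also open is whether 4-(methylsulfonyl)phenyl would keep its number with a shorter chain in place of the one the compounds share.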